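Working notes: bromo in place of methoxy, compound 4

The source may report more compounds than this note shows. Statements on the series, on what has been measured and on what is new or still open speak of the compounds shown alone.

Values in a functional assay for inhibition, with Homo sapiens as the target (on this read-out lower numbers stand for tighter binding and higher numbers for weaker binding), for the measured compounds:
- compound 1 `Cc1ccc(C#N)c(OC(C)(C)C2OCC(C/C=C\CCC(=O)O)C(c3cccnc3)O2)c1` gives 15.9 nM
- compound 2 `CC(C)(Oc1ccccc1F)C1OCC(C/C=C\CCC(=O)O)C(c2cccnc2)O1` gives 166 nM
- compound 3 `COc1ccccc1OC(C)(C)C1OCC(C/C=C\CCC(=O)O)C(c2cccnc2)O1` gives 224 nM

Compound 3 cannot be separated from compound 2 on these numbers, with a 1.3-fold higher number from compound 2 to compound 3 (0.13 log units; within the scatter) as the measured step. Both lie well away from compound 1, as shown by a 10-fold higher number from compound 1 to compound 2 (1.02 log units; beyond the scatter) and by a 14-fold higher number from compound 1 to compound 3 (1.15 log units; beyond the scatter). Compound 4 `CC(C)(Oc1ccccc1Br)C1OCC(C/C=C\CCC(=O)O)C(c2cccnc2)O1` carries bromo in place of methoxy on an aromatic carbon, ortho to a large group, and the counted difference is bromo in place of methoxy on an aromatic carbon. The two large steps replace the whole 2-cyano-5-methylphenyl group, so they bear only weakly on this exchange. Among the measured compounds shown here, the closest precedent is the exchange of fluoro and methoxy between compound 2 and compound 3, which stayed within the scatter. For the measured compounds named here, no bromo compound has been measured yet. The expected change is a 1.5-fold lower number from compound 3 to compound 4 (0.17 log units; within the scatter), so no step beyond the scatter is expected in this assay. The estimate for compound 4 is 150 nM, with an expected range from 60 nM to 400 nM.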

Compound 4, dissociation constant: 63.1 nM
Compound 4: the middle estimate sits 2.4-fold (0.38 log units) above what was measured, within the range that was stated.
By their numbers in this assay, from the lowest: compound 1; then compound 4; then compounds 2 and 3 (each within the scatter of the next).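

In this assay the substituent on this aromatic carbon, ortho to a large group, now separates compounds beyond the scatter: bromo in place of methoxy gives a 3.5-fold lower number from compound 3 to compound 4 (0.55 log units; beyond the scatter) and bromo in place of fluoro gives a 2.6-fold lower number from compound 2 to compound 4 (0.42 log units; beyond the scatter), whereas the fluoro and methoxy pair could not be separated. The 2-bromophenyl group closes part of the gap to the 2-cyano-5-methylphenyl group but not all of it, leaving a 4.0-fold higher number from compound 1 to compound 4 (0.60 log units; beyond the scatter). No independent measurement is available to explain why bromo differs from the other two groups.

Going by these compounds, compound 1 differs from compound 4 in two features of the aromatic ring, so the shares of the cyano and methyl groups in the remaining gap stay open. On these data alone, how chloro or an amine would read on this same aromatic carbon also stays open.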